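This account rests on a few compounds, and the source may have more. Where it says the series, first, only, none or still open, it means among the compounds named here.

Measured so far in a functional assay on MCF7 cells (Homo sapiens) for antiproliferative activity, read by CellTiter-Glo, with a stated time of 5 days; on this read-out higher numbers stand for weaker inhibition and lower numbers for stronger inhibition:
Compound 1 `CC/C(=C(/c1ccc(/C=C/C(=O)O)cc1)c1ccn2nncc2c1)c1ccccc1`: > 500 nM
Compound 2 `CC/C(=C(/c1ccc(/C=C/C(=O)O)cc1)c1ccc(-c2nccs2)cc1)c1ccccc1`: 290 nM

Compound 1 shows the entry > 500 nM, which is a limit of the assay and not a number.

For the measured compounds named here, compound 2, at 290 nM, therefore holds the only true number in this assay so far.

Compound 3 `CC/C(=C(/c1ccc(/C=C/C(=O)O)cc1)c1ccc(N2CCCCC2)cc1)c1ccccc1` is the next to be read. It keeps the rest of compound 2 and carries piperidin-1-yl in place of 1,3-thiazol-2-yl on an aromatic carbon, para to a large group: piperidin-1-yl in place of 1,3-thiazol-2-yl on an aromatic carbon.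

Going by the values given here, no measured step between two compounds shows what a change at this place does. The expectation in this assay is therefore for no change beyond the scatter, in either direction.

The expected outcome is a 1.0-fold higher number from compound 2 to compound 3 (0.01 log units; within the scatter).

For compound 3 the estimated value is 300 nM, with an expected range of 90 nM to 900 nM.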

Compound 3, half-maximal inhibitory concentration: 450 nM
The estimate for compound 3 lay 1.5-fold (0.18 log units) below the measured number; the range from low to high includes it.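

In this assay, the place on an aromatic carbon, para to a large group, now has its first measured step: piperidin-1-yl in place of 1,3-thiazol-2-yl gives a 1.6-fold higher number from compound 2 to compound 3 (0.19 log units; within the scatter). A five-membered aromatic ring with two hetero atoms and a six-membered non-aromatic ring with one hetero atom are therefore not told apart at this place, so aromaticity of the group is not shown to matter here. Compound 1 stands at a limit and not at a number, which leaves the readable range short: the limit of > 500 nM in this assay, at which 1 of the 3 values shown sits.

The compounds shown leave open whether a morpholin-4-yl ring, a phenyl ring or an open-chain dimethylamino group at this place would read any differently. They also leave open whether an amide in place of the carboxylic acid would change the reading.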